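This account rests on a few compounds, and the source may have more. Where it says the series, first, only, none or still open, it means among the compounds named here.

Measured compounds and their values in a functional assay (Pituitary gland cell) with Rattus norvegicus as the target; on this read-out lower numbers stand for an effect already at smaller amounts and higher numbers for an effect only at larger amounts of compound:
compound 1, `CC(C)(N)C(=O)N[C@@H]1CCc2ccccc2N(Cc2ccc(-c3ccccc3-c3nn[nH]n3)cc2)C1=O`: 0.03 uM
compound 2, `CC(C)(N)CCSC1CCc2ccccc2N(Cc2ccc(-c3ccccc3-c3nn[nH]n3)cc2)C1=O`: 6 uM
compound 3, `CC(C)(N)CCCSC1CCc2ccccc2N(Cc2ccc(-c3ccccc3-c3nn[nH]n3)cc2)C1=O`: 7 uM

Among these three, compound 1 stands lowest, and its gap to compound 2 and to compound 3 lies far beyond the usual scatter. Compound 2 and compound 3 carry a thioether linkage where compound 1 carries an amide, and they differ from each other only in the amine-bearing chain: a 1.2-fold higher number from compound 2 to compound 3 (0.07 log units; within the scatter).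

The unmeasured compound 4, `CN(C(=O)CC(C)(C)N)[C@@H]1CCc2ccccc2N(Cc2ccc(-c3ccccc3-c3nn[nH]n3)cc2)C1=O`, keeps the amide of compound 1 but alters it: ((2-amino-2-methylpropyl)carbonyl)(methyl)amino in place of ((1-amino-1-methylethyl)carbonyl)amino on a saturated ring carbon. Among the compounds with values here, no measured step tests this change directly. The step from compound 2 to compound 3 shows that exchanging 1-amino-1-methylethyl for 2-amino-2-methylpropyl changed nothing beyond the scatter, and the longer chain in compound 4 is of the same kind. Within the data shown here, the methyl on the amide nitrogen has no counterpart among the measured compounds, while the wide gap between compound 1 and compound 2 shows that changes in the linker region can cost a great deal. A moderate rise in the number is therefore expected in this assay for compound 4: a 10-fold higher number from compound 1 to compound 4 (1.00 log units; beyond the scatter). Compound 4 is estimated at 0.3 uM, with a range from 0.05 uM to 3 uM.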

Compound 4, concentration for half-maximal effect: 7 uM
The estimate for compound 4 lay 23-fold (1.37 log units) below the measured number, and the stated range ends below it.
By their numbers in this assay, from the lowest: compound 1; then compounds 2, 3 and 4 (each within the scatter of the next).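

In this assay, replacing ((1-amino-1-methylethyl)carbonyl)amino with ((2-amino-2-methylpropyl)carbonyl)(methyl)amino on this saturated ring carbon gives a 230-fold higher number from compound 1 to compound 4 (2.37 log units; beyond the scatter), so keeping an amide at this position is not enough to keep the low number. The thioether pair had suggested that the longer amine-bearing chain might cost little, with a 1.2-fold higher number from compound 2 to compound 3 (0.07 log units; within the scatter), but this change also puts a methyl in place of the amide hydrogen, and together the two alterations cost a great deal. No measurement bears on why the number rises so steeply here.

The single step cannot divide the rise between the added methyl on the amide nitrogen and the longer chain, and the compounds shown leave that split open. The groups that would separate the two are ((2-amino-2-methylpropyl)carbonyl)amino, which has the longer chain and keeps the amide hydrogen, and ((1-amino-1-methylethyl)carbonyl)(methyl)amino, which has the shorter chain and carries the methyl.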